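A Chloro Added Beside a Trifluoromethyl Urea Tail

A few compounds are considered here, and "the series" means these few. Any claim that something is new, unique, unknown or untested is made for them only; others in the source may bear on it.

Of the compounds shown here, two that share one core have been tested in a functional assay on A549 cells (Homo sapiens) for inhibition, read by sulforhodamine B assay, with a stated time of 48 h, tested at 10 uM; on this read-out higher numbers stand for a weaker effect at the one concentration tested and lower numbers for a stronger effect. Compound 1 `COc1cc2cc(Oc3ccc(NC(=O)Nc4ccccc4)cc3)c(C)nc2cc1OC` carries an unsubstituted phenyl on the urea and gives 58.4%. Compound 2 `COc1cc2cc(Oc3ccc(NC(=O)Nc4cccc(C(F)(F)F)c4)cc3)c(C)nc2cc1OC` carries a 3-(trifluoromethyl)phenyl there and gives 3.09%. Going by the values given here, the step of a number 55.3 percentage points lower from compound 1 to compound 2 (beyond the scatter) is the only measured step so far, and it shows that a single group on this urea ring can change the read-out a great deal. On the numbers shown, compound 2 stands lowest, that is strongest, and its nearest neighbour is compound 1.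

Compound 3 `COc1cc2cc(Oc3ccc(NC(=O)Nc4ccc(Cl)c(C(F)(F)F)c4)cc3)c(C)nc2cc1OC` has not been measured. It differs from compound 2 by chloro in place of hydrogen on an aromatic carbon, turning the 3-(trifluoromethyl)phenyl into a 4-chloro-3-(trifluoromethyl)phenyl. Among the compounds with values here, no measured step involves a chloro entering at this place, so the one step available bears only indirectly, by showing the tail is sensitive. Because compound 2 already sits at 3.09%, there is little room for a further fall, and the step is expected to be none beyond the scatter. Compound 3 is expected to give about 4%, within a range from 0% to 15%. This means an expected step of a number 0.9 percentage points higher from compound 2 to compound 3 (within the scatter).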

Compound 3, a percentage reported as activity, at one concentration (the size of the read-out at that concentration, not a potency): -17.3%
The estimate for compound 3 lay 21.3 percentage points above the measured number, and the stated range ends above it.
By their numbers in this assay, from the lowest: compound 3; then compound 2; then compound 1.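

In this assay the chloro, placed ortho to a trifluoromethyl group and para to a large group, still moves the number by a number 20.4 percentage points lower from compound 2 to compound 3 (beyond the scatter), so this ring position takes a further group on top of the trifluoromethyl, and a compound already low on this read-out can go lower, with compound 3 at -17.3% on the far side of zero. Taken whole, replacing the plain phenyl with 4-chloro-3-(trifluoromethyl)phenyl gives a number 75.7 percentage points lower from compound 1 to compound 3 (beyond the scatter), the largest step among these three compounds. Nothing available explains why the chloro has this effect.

Still open, on these data alone, is whether the chloro itself matters or any group at this place would do the same, a question that a fluoro, a bromo, a methyl or a methoxy in the same spot could help answer. Also open is how much of the full step belongs to each group, since a tail carrying the chloro alone, without the trifluoromethyl, is not among the compounds shown here.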